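A few compounds are considered here, and "the series" means these few. Any claim that something is new, unique, unknown or untested is made for them only; others in the source may bear on it.

Compound 1 `COc1cc(C)cc(-c2c(-c3ccnc(-c4ccc(C(C)=O)cc4)c3)cnn2CC#N)c1` gives 3120 nM in a functional assay on BT-549 cells (Homo sapiens) for inhibition, read by sulforhodamine B assay, with a stated time of 48 h; a lower number here means a stronger inhibitor of growth, a higher number a weaker inhibitor of growth; compound 2 `COc1cc(C)cc(-c2nn(CC#N)cc2-c2ccc(-c3cccc(C(C)=O)c3)nc2)c1` gives 2730 nM; compound 3 `Cc1cc(O)cc(-c2nn(CC#N)cc2-c2ccnc(-c3ccc(Oc4ccccc4)cc3)c2)c1` gives 2660 nM.

Compound 3 holds the lowest of the three numbers in this assay, but the gaps to compound 2 and to compound 1 both lie within the usual scatter, so the three cannot be told apart. No pair of these compounds differs in a single place, so no measured step guides the next one. Compound 4 `Cc1cc(O)cc(-c2nn(CC#N)cc2-c2ccnc(-c3ccc(N(C)C)cc3)c2)c1` differs from compound 3 in one place: dimethylamino in place of phenoxy on an aromatic carbon. For the measured compounds named here, with no measured step of this kind, compound 4 is expected to stay near compound 3, the step from a 1.0-fold lower number from compound 3 to compound 4 (0.01 log units; within the scatter) being estimated as none beyond the scatter. Compound 4 is therefore estimated at 2600 nM, with a range from 900 nM to 7500 nM.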

Compound 4, concentration for 50% growth inhibition: 2770 nM
Compound 4: middle estimate off by 1.1-fold (0.03 log units), on the low side; measured number inside the range.
By their numbers in this assay, from the lowest: compounds 3, 2, 4 and 1 (each within the scatter of the next).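

In this assay, dimethylamino in place of phenoxy gives a 1.0-fold higher number from compound 3 to compound 4 (0.02 log units; within the scatter). At this place, para to a large group, the six-membered aromatic ring of carbon only can thus leave, and the group can go from 7 heavy atoms to 3, with no change beyond the scatter. Nothing at hand gives a reason for this result.

The compounds shown leave open whether any other group at this place, such as a carboxylic acid or a morpholine, would move the number beyond the scatter.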